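Notes on acetyl in place of methoxy

This account rests on a few compounds, and the source may have more. Where it says the series, first, only, none or still open, it means among the compounds named here.

Of the compounds shown here, three with a shared core have been read so far in a physicochemical assay for solubility (on this read-out lower numbers stand for lower solubility and higher numbers for higher solubility), on this series. Compound 1 `COc1ccc(Cl)cc1C(=O)Nc1ccc([N+](=O)[O-])cc1Cl` returns < 1 ug/mL as its result, which is a limit of the assay and not a number. Compound 2 `O=C(Nc1ccc([N+](=O)[O-])cc1Cl)c1ccc(Cl)cc1O` gives 1.1 ug/mL as a measured number, and compound 3 `COc1ccc(O)c(C(=O)Nc2ccc([N+](=O)[O-])cc2Cl)c1` gives 2.1 ug/mL as the other. These two numbers lie within the scatter of each other, so compound 3 stands together with compound 2 and no order can be read between them.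

Compound 4 `CC(=O)c1ccc(O)c(C(=O)Nc2ccc([N+](=O)[O-])cc2Cl)c1` is next to be read. Relative to compound 3 it carries acetyl in place of methoxy on an aromatic carbon, para to a hydroxy group (acetyl in place of methoxy on an aromatic carbon). Going by the values given here, no two measured compounds differ in one place, so the series gives no measured size for such a change in this assay, and no step beyond the scatter is expected. A limit reading for compound 4 remains possible, given the limit of < 1 ug/mL in this assay, at which 1 of the 3 values shown sits, and nothing more. The expected step of a 1.2-fold lower number from compound 3 to compound 4 (0.07 log units; within the scatter) is estimated to lie within the scatter. For compound 4 the estimate is 1.8 ug/mL with an expected range from 1 ug/mL to 4 ug/mL as its spread.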

Compound 4, solubility: > 49 ug/mL
Compound 4: a limit, no number; the forecaster's own chance of this, stated with the estimate: 15%; middle value at least 27-fold (1.43 log units) from the limit.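

In this assay, going by these compounds alone, acetyl in place of methoxy on an aromatic carbon, para to a hydroxy group, gives an at least 23-fold higher number from compound 3 to compound 4 (1.36 log units; beyond the scatter), the first step between compounds that differ in one place. Within the data shown here, compound 4 reads as a limit of the assay and not as a number, so the step has a floor but no measured size: the limit of > 49 ug/mL in this assay, at which 1 of the 4 values shown sits. This position therefore responds strongly in this assay to a single change of group, which the earlier compounds could not show, as none of them formed such a pair.

The compounds shown rest on this one replacement at this one position, so it stays open whether a carboxylic acid, an amine or a longer chain ending in a carbonyl in the same place would read like acetyl or like methoxy. The series also holds no measured property that accounts for the step, and it has no second pair to show whether the same replacement would give a step of this kind on a different core.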